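The source may report more compounds than this note shows. Statements on the series, on what has been measured and on what is new or still open speak of the compounds shown alone.

Of the compounds shown here, three of one shared core have been measured for cytotoxicity. In an ADME assay on Huh-7 cells (Homo sapiens) for cytotoxicity, read by MTT assay, with a stated time of 48 h (on this read-out higher numbers stand for lower toxicity in this test and lower numbers for higher toxicity in this test), compound 3 `CN(C)CCCCOC(=O)Nc1ccc(Cn2nc(-c3ccncc3)c3ccccc3c2=O)cc1` gives 62700 nM, the highest of the three numbers. Compound 2 `CN(C)CCCC(=O)Nc1ccc(CN2N=C(c3ccc(F)cc3)C3C=CC=CC3C2=O)cc1` gives 38200 nM in this assay, a number that lies within the scatter of compound 3. Compound 1 `CN(C)CCCCN(C(=O)O)c1cccc(Cn2nc(-c3ccc(F)cc3)c3ccccc3c2=O)c1` gives 8510 nM in this assay, which lies beyond that scatter. Compound 4 `CN(C)CCCCOC(=O)Nc1ccc(Cn2nc(-c3ccc(C#N)cc3)c3ccccc3c2=O)cc1` has not yet been measured; it differs from compound 3 by 4-cyanophenyl in place of pyridin-4-yl on an aromatic carbon. Within the data shown here, no measured pair shows the effect of this change, so any expectation rests only on the numbers above. The step of a 1.3-fold lower number from compound 3 to compound 4 (0.10 log units; within the scatter) is expected to be small, not beyond the scatter in either direction. Compound 4 is therefore expected to give about 50000 nM, in a range from 20000 nM to 120000 nM.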

Compound 4, half-maximal cytotoxic concentration: 37000 nM
The estimate for compound 4 lay 1.4-fold (0.13 log units) above the measured number; low and high end bracket the measured number.
By their numbers in this assay, from the lowest: compound 1; then compounds 4, 2 and 3 (each within the scatter of the next).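

In this assay, among these compounds, this pair gives the first direct reading at this position: a 1.7-fold lower number from compound 3 to compound 4 (0.23 log units; within the scatter) puts the two compounds within the usual scatter of each other. At this level of resolution, 4-cyanophenyl and pyridin-4-yl on this aromatic carbon cannot be told apart. Nothing measured here offers an explanation for this result. Still open, on these data alone, is whether a plain phenyl, a carboxylic acid or an amine on this carbon would also stay within the scatter of compound 3.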